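Anilide variation on a nitrobenzofurazan thioether ester

This account rests on a few compounds, and the source may have more. Where it says the series, first, only, none or still open, it means among the compounds named here.

Measured so far in a functional assay on HOS cells (Homo sapiens) for inhibition, read by MTT assay, with a stated time of 72 h; on this read-out lower numbers stand for stronger inhibition and higher numbers for weaker inhibition:
compound 1 `O=C(O)CCC(=O)OCCCCCCSc1ccc([N+](=O)[O-])c2nonc12` gives 8740 nM
compound 2 `Cc1ccccc1NC(=O)CCC(=O)OCCCCCCSc1ccc([N+](=O)[O-])c2nonc12` gives 4020 nM
compound 3 `O=C(CCC(=O)OCCCCCCSc1ccc([N+](=O)[O-])c2nonc12)Nc1cccc(Cl)c1` gives 1920 nM

Compound 3 stands lowest of the three in this assay ; its nearest neighbour is compound 2, and the step of a 2.1-fold lower number from compound 2 to compound 3 (0.32 log units; beyond the scatter) is beyond the scatter, as is the longer step of a 4.6-fold lower number from compound 1 to compound 3 (0.66 log units; beyond the scatter).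

Compound 4 `COc1ccc(NC(=O)CCC(=O)OCCCCCCSc2ccc([N+](=O)[O-])c3nonc23)cc1OC` has not yet been measured. Against compound 3 the change is 3,4-dimethoxyphenyl in place of 3-chlorophenyl on an amide-type nitrogen.

For the measured compounds named here, two measured steps bear on the aryl group of the anilide. Replacing the hydroxy of the acid by an arylamino lowered the number in both cases, a 2.2-fold lower number from compound 1 to compound 2 (0.34 log units; beyond the scatter) and a 4.6-fold lower number from compound 1 to compound 3 (0.66 log units; beyond the scatter). Between the two aryl groups themselves the step of a 2.1-fold lower number from compound 2 to compound 3 (0.32 log units; beyond the scatter) is modest. Going by the values given here, compound 4 keeps the anilide, so a number in the range of compound 2 and compound 3 is expected; there is no measured step for a dimethoxy-substituted ring, and the 3,4-dimethoxyphenyl group is not the chlorinated ring that gave the lowest number, so a modest rise relative to compound 3 is expected rather than a further fall, with wide uncertainty.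

Compound 4 is therefore estimated at 3000 nM, between 1200 nM and 8000 nM, which means an expected step of a 1.6-fold higher number from compound 3 to compound 4 (0.19 log units; within the scatter).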

Compound 4, half-maximal inhibitory concentration: 1390 nM
Compound 4: the middle estimate sits 2.2-fold (0.33 log units) above what was measured; the measured number falls inside the stated range.
By their numbers in this assay, from the lowest: compounds 4 and 3 (each within the scatter of the next); then compound 2; then compound 1.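

In this assay, 3,4-dimethoxyphenyl in place of 3-chlorophenyl on the amide-type nitrogen gives a 1.4-fold lower number from compound 3 to compound 4 (0.14 log units; within the scatter), so these two anilides cannot be told apart and chlorine is not required for a number in this range. The dimethoxy anilide stands clear of the 2-methylphenyl anilide, with a 2.9-fold lower number from compound 2 to compound 4 (0.46 log units; beyond the scatter), and of the free acid, with a 6.3-fold lower number from compound 1 to compound 4 (0.80 log units; beyond the scatter); among the anilides shown, compound 2 is therefore the one set apart from the other two, while all three lie beyond the scatter from compound 1. No measured evidence is available on why the aryl groups read as they do.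

The compounds shown do not separate the effect of the methyl group itself from that of where it sits on the ring. Also open, on these data alone, is how a plain phenyl anilide, a ring bearing an amine or a carboxylic acid, or a longer chain in place of the one joining the ester to the sulfur would read in this assay.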